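The source may hold more compounds than are shown below. What is called first, only, known or untested is meant among the compounds shown, and "the series" means these compounds.

Compound 3 `COc1cc(C2C(C#N)=C(N)Oc3cc(N)ccc32)cc(Br)c1OC` stands second highest of the three numbers in a functional assay on T47D cells (Homo sapiens) for activation; a higher number here means that more compound is needed for the effect, a lower number that less compound is needed: compound 3 gives 33000000 nM, while compound 2 `COc1ccc2c(c1)OC(N)=C(C#N)C2c1cc(Br)c(OC)c(OC)c1` gives 17000000 nM and compound 1 `COc1cc(C2C(C#N)=C(N)Oc3cc(Br)ccc32)cc(Br)c1OC` gives 140000000 nM. The measured steps were an 8.2-fold lower number from compound 1 to compound 2 (0.92 log units; beyond the scatter) and a 4.2-fold lower number from compound 1 to compound 3 (0.63 log units; beyond the scatter), both modest, and a 1.9-fold higher number from compound 2 to compound 3 (0.29 log units; within the scatter), within the scatter. Compound 4 `CCNc1ccc2c(c1)OC(N)=C(C#N)C2c1cc(Br)c(OC)c(OC)c1` differs from compound 3 by ethyl in place of hydrogen on a nitrogen on an aromatic ring. Going by the values given here, none of the measured steps touches the nitrogen in this way; all of them swap the group on the aromatic carbon, so they bear on this change only loosely. The expectation for compound 4 is therefore a step of a 1.3-fold lower number from compound 3 to compound 4 (0.12 log units; within the scatter), not beyond the scatter. Compound 4 is estimated at 25000000 nM, within a range from 8000000 nM to 80000000 nM.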

Compound 4, half-maximal effective concentration: 14000000 nM
For compound 4 the middle estimate is 1.8-fold (0.25 log units) above the measured one; low and high end bracket the measured number.
By their numbers in this assay, from the lowest: compounds 4, 2 and 3 (each within the scatter of the next, the first and the last beyond it); then compound 1.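

Going by these compounds alone, putting ethyl on the nitrogen is the first change made at that nitrogen itself, and in this assay it has a modest effect beyond the scatter (a 2.4-fold lower number from compound 3 to compound 4 (0.37 log units; beyond the scatter)). Ethylamino on the aromatic carbon cannot be told apart from methoxy there (a 1.2-fold lower number from compound 2 to compound 4 (0.08 log units; within the scatter)), while replacing bromo with ethylamino gives a clearer difference (a 10-fold lower number from compound 1 to compound 4 (1.00 log units; beyond the scatter)). No measurement shown explains these differences. As far as these compounds go, a single ethyl step sets no trend, so a longer chain such as propyl on this nitrogen, or an acetyl group there, remains open.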